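This account rests on a few compounds, and the source may have more. Where it says the series, first, only, none or still open, it means among the compounds named here.

In a functional assay on MDA-MB-231 cells (Homo sapiens) for cytotoxicity, read by MTT assay, with a stated time of 72 h (on this read-out higher numbers stand for weaker inhibition and lower numbers for stronger inhibition), compound 1 `CCN(CC)Cc1ccc2nc(NC(=O)N/N=C/c3cn(Cc4ccc(Cl)cc4Cl)c4ccccc34)sc2c1` gives 3280 nM while compound 2 `CCN(CC)Cc1ccc2nc(NC(=O)N/N=C/c3cn(Cc4ccc(C)cc4)c4ccccc34)sc2c1` gives 2010 nM and compound 3 `CCN(CC)Cc1ccc2nc(NC(=O)N/N=C/c3c[nH]c4ccccc34)sc2c1` gives 1900 nM on the shared core. All three numbers lie within the scatter of one another, so compound 2 sits in a single group with the other two. Compound 4 `Cc1ccc(Cn2cc(/C=N/NC(=O)Nc3nc4ccc(CN(C)C)cc4s3)c3ccccc32)cc1` has not been measured yet and differs from compound 2 in one place (dimethylamino in place of diethylamino on a saturated chain carbon bound to an aromatic carbon): dimethylamino in place of diethylamino on a saturated chain carbon bound to an aromatic carbon. Among the measured compounds shown here, no measured step touches this amino group. The three available steps (a 1.6-fold lower number from compound 1 to compound 2 (0.21 log units; within the scatter); a 1.7-fold lower number from compound 1 to compound 3 (0.24 log units; within the scatter); a 1.1-fold lower number from compound 2 to compound 3 (0.02 log units; within the scatter)) all alter the group on an aromatic nitrogen, and each stays within the scatter. They are therefore only indirect evidence, but with nothing pointing either way, no step beyond the scatter is expected in this assay here. The expected outcome is a small step (a 1.0-fold lower number from compound 2 to compound 4 (0.00 log units; within the scatter)). For compound 4 the estimated value is 2000 nM with an expected range from 1000 nM to 4000 nM as a deliberately wide allowance.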

Compound 4, half-maximal inhibitory concentration: 1220 nM
For compound 4 the middle estimate is 1.6-fold (0.21 log units) above the measured one; the range from low to high includes it.
By their numbers in this assay, from the lowest: compounds 4, 3, 2 and 1 (each within the scatter of the next, the first and the last beyond it).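

Among the compounds shown here, this pair gives the first reading at the amino group on the saturated chain carbon bound to an aromatic carbon, as every earlier step altered the group on an aromatic nitrogen. In this assay the move from diethylamino to dimethylamino, from 5 heavy atoms to 3, comes with a 1.6-fold lower number from compound 2 to compound 4 (0.22 log units; within the scatter) and so does not separate the two compounds, which means this single change gives no sign that the shorter chains on the amine matter in this assay. Nothing measured here accounts for the size of this step.

The compounds shown leave open whether a ring amine such as piperidine, or a carboxylic acid, in this place would give a step beyond the scatter. For the compounds shown here, also open is how dimethylamino behaves with hydrogen or 2,4-dichlorobenzyl on the aromatic nitrogen, as the one pair here carries 4-methylbenzyl there.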